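A few compounds are considered here, and "the series" means these few. Any claim that something is new, unique, unknown or untested is made for them only; others in the source may bear on it.

Of the compounds shown here, three built on one shared core have been measured in a functional assay on UO-31 cells (Homo sapiens) for inhibition, read by sulforhodamine B assay, with a stated time of 48 h; on this read-out lower numbers stand for stronger inhibition of growth and higher numbers for weaker inhibition of growth. Compound 2 `COc1cc(-c2nn(-c3cccc(NC(=O)c4ccc(Cl)c(C(F)(F)F)c4)c3)cc2-c2ccncc2)ccc1Cl` gives 267 nM, the lowest of the three numbers. Compound 3 `COc1cc(-c2nn(-c3cccc(NC(=O)Nc4cccc(C(F)(F)F)c4)c3)cc2-c2ccncc2)ccc1Cl` gives 702 nM, and compound 1 `O=C(Nc1cccc(-n2cc(-c3ccncc3)c(-c3ccc(Cl)c(O)c3)n2)c1)Nc1ccc(Cl)c(Cl)c1`, which carries a different set of groups around the same core, gives 1250 nM. The step of a 2.6-fold higher number from compound 2 to compound 3 (0.42 log units; beyond the scatter) bundles two changes at once, so it speaks only partly to the question at hand. Compound 4 `COc1cc(-c2nn(-c3cccc(NC(=O)Nc4ccc(Cl)c(C(F)(F)F)c4)c3)cc2-c2ccncc2)ccc1Cl` differs from compound 2 in a single place: (4-chloro-3-(trifluoromethyl)phenyl)amino in place of 4-chloro-3-(trifluoromethyl)phenyl on a carbonyl carbon. Among the compounds with values here, no measured pair isolates exactly this change; the one step that contains it, from compound 2 to compound 3, was a modest weakening, and it shares with the present change the alteration at the carbonyl carbon. A modest rise in the number is therefore expected, with a 1.9-fold higher number from compound 2 to compound 4 (0.27 log units; within the scatter) as the estimated step. Compound 4 is expected to give about 500 nM, with a plausible range from 200 nM to 1300 nM.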

Compound 4, concentration for 50% growth inhibition: 865 nM
For compound 4 the middle estimate is 1.7-fold (0.24 log units) below the measured one; the range from low to high includes it.
By their numbers in this assay, from the lowest: compound 2; then compounds 3, 4 and 1 (each within the scatter of the next).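

With the aryl group held constant, adding only the amino link on the carbonyl carbon gives a 3.2-fold higher number from compound 2 to compound 4 (0.51 log units; beyond the scatter) in this assay, so this change on its own weakens growth inhibition. Chloro in place of hydrogen on an aromatic carbon gives a 1.2-fold higher number from compound 3 to compound 4 (0.09 log units; within the scatter), which cannot be told apart from repeat scatter, so the weakening seen in a 2.6-fold higher number from compound 2 to compound 3 (0.42 log units; beyond the scatter) follows the added amino group rather than the missing chloro. No supporting data explain why the added amino group goes with a higher number.

Going by these compounds, it remains open how a methylene group or an oxygen atom would compare with the amino group in the same place on the carbonyl carbon. Also open, on these data alone, is whether removing the chloro would matter as little in compound 2, where the aryl group sits on the carbonyl carbon without an amino link.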